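A few compounds are considered here, and "the series" means these few. Any claim that something is new, unique, unknown or untested is made for them only; others in the source may bear on it.

Measured so far in a functional assay on A549 cells (Homo sapiens) for antiproliferative activity, read by CCK-8 assay, with a stated time of 72 h; a lower number here means a stronger inhibitor, a higher number a weaker inhibitor:
- compound 1 `Cc1ccc(C(=O)Nc2cccc(-c3oc4cc(-c5ccc(F)cc5)ccc4c(=O)c3O)c2)cc1`: 6910 nM
- compound 2 `Cc1cc(C)cc(C(=O)Nc2cccc(-c3oc4cc(-c5ccc(F)cc5)ccc4c(=O)c3O)c2)c1`: 3740 nM

Within the data shown here, compound 2 holds the lower of the two numbers, but its one neighbour, compound 1, sits at a 1.8-fold lower number from compound 1 to compound 2 (0.27 log units; within the scatter), within the scatter, so no ranking is established. Compound 3 `N#Cc1ccc(C(=O)Nc2cccc(-c3oc4cc(-c5ccc(F)cc5)ccc4c(=O)c3O)c2)cc1` differs from compound 2 by 4-cyanophenyl in place of 3,5-dimethylphenyl on a carbonyl carbon. Among the measured compounds shown here, the single measured step, a 1.8-fold lower number from compound 1 to compound 2 (0.27 log units; within the scatter), exchanges one methyl-bearing phenyl for another and says nothing about a 4-cyanophenyl; no other step bears on the change. Compound 3 is therefore expected to move by a 1.2-fold higher number from compound 2 to compound 3 (0.08 log units; within the scatter), with wide uncertainty. Compound 3 is estimated at 4500 nM, between 1500 nM and 14000 nM.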

Compound 3, half-maximal inhibitory concentration: 2360 nM
Estimate against measurement, compound 3: 1.9-fold (0.28 log units) above; the measured number falls inside the stated range.
By their numbers in this assay, from the lowest: compounds 3, 2 and 1 (each within the scatter of the next, the first and the last beyond it).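

In this assay, among these compounds, cyano in place of methyl on an aromatic carbon gives the first step at this position beyond the scatter, a 2.9-fold lower number from compound 1 to compound 3 (0.47 log units; beyond the scatter), though it is modest. The step of a 1.6-fold lower number from compound 2 to compound 3 (0.20 log units; within the scatter) stays within the scatter, so 4-cyanophenyl and 3,5-dimethylphenyl are not separated on a carbonyl carbon. No measurement shown here accounts for either step.

As far as these compounds go, how an amine or a carboxylic acid would read in place of cyano on an aromatic carbon remains open. Also open, from the compounds shown here alone, is whether a longer chain there would give a step larger than this modest one.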